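Same aryl swap on a second core: expectation for compound 4

The source may report more compounds than this note shows. Statements on the series, on what has been measured and on what is new or still open speak of the compounds shown alone.

Compound 1 `O=C(Nc1ccc(Oc2ccnc3[nH]ccc23)cc1)c1nn(-c2ccc(Br)cc2F)ccc1=O` is the reference point of the set. In a functional assay on HepG2 cells (Homo sapiens) for cytotoxicity, read by MTT assay, with a stated time of 72 h (on this read-out lower numbers stand for stronger inhibition and higher numbers for weaker inhibition), compound 1 gives 46400 nM. Compound 2 `O=C(Nc1ccc(Oc2ccnc3[nH]ccc23)cc1)c1nn(-c2ccc(Cl)c(F)c2)ccc1=O` carries 4-chloro-3-fluorophenyl in place of 4-bromo-2-fluorophenyl on an aromatic nitrogen; in this assay compound 2 gives 5240 nM, a step of an 8.9-fold lower number from compound 1 to compound 2 (0.95 log units; beyond the scatter). Compound 3 `Cn1ccc2c(Oc3ccc(NC(=O)c4nn(-c5ccc(Br)cc5F)ccc4=O)cc3)ccnc21` differs from compound 1 in the core by methyl in place of hydrogen on an aromatic nitrogen; in this assay compound 3 gives 31200 nM, a step of a 1.5-fold lower number from compound 1 to compound 3 (0.17 log units; within the scatter), so the core change by itself changes little here. Compound 4 `Cn1ccc2c(Oc3ccc(NC(=O)c4nn(-c5ccc(Cl)c(F)c5)ccc4=O)cc3)ccnc21` is not yet measured. It differs from compound 3 by 4-chloro-3-fluorophenyl in place of 4-bromo-2-fluorophenyl on an aromatic nitrogen, which is the same change as that from compound 1 to compound 2, the place being described in the same words, and it occurs twice among these four compounds. The expectation rests on that single measured pairing. Because an 8.9-fold lower number from compound 1 to compound 2 (0.95 log units; beyond the scatter) lies beyond the scatter while a 1.5-fold lower number from compound 1 to compound 3 (0.17 log units; within the scatter) lies within it, compound 4 is expected to shift by a 7.8-fold lower number from compound 3 to compound 4 (0.89 log units; beyond the scatter). With one pairing only, the expectation is held loosely and the range kept wide. Compound 4 is estimated at 4000 nM, with a likely span from 1500 nM to 12000 nM.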

Compound 4, half-maximal inhibitory concentration: > 60000 nM
Compound 4 ended at the assay's limit (the forecaster's own chance of this, stated with the estimate: 5%); at least 15-fold (1.17 log units) between middle value and limit.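

Compound 4 gives > 60000 nM in this assay, which is a limit of the assay and not a number, so both steps into it are floors. Read as a floor, the aryl swap gives an at least 1.9-fold higher number from compound 3 to compound 4 (0.28 log units; that floor lies within the scatter), so the gain seen on the core of compound 1 does not carry over to the core of compound 3: the same change on two cores in this assay, an 8.9-fold lower number (0.95 log units; beyond the scatter) from compound 1 to compound 2 and an at least 1.9-fold higher number (0.28 log units; that floor lies within the scatter) from compound 3 to compound 4, at least 17-fold (1.23 log units) apart, beyond the scatter of two such steps The methyl on the aromatic nitrogen gives an at least 11-fold higher number from compound 2 to compound 4 (1.05 log units; beyond the scatter), whereas its step with 4-bromo-2-fluorophenyl stayed within the scatter, but this single square of compounds shows only that the two changes do not add here, not how far compound 4 lies past the limit or why: the same change on two cores in this assay, a 1.5-fold lower number (0.17 log units; within the scatter) from compound 1 to compound 3 and an at least 11-fold higher number (1.05 log units; beyond the scatter) from compound 2 to compound 4, at least 17-fold (1.23 log units) apart, beyond the scatter of two such steps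

On these data alone, it remains open whether this dependence holds for aryl groups other than these two. As far as these compounds go, it is also open whether an ethyl group or a longer chain ending in an amine, in place of the methyl, would behave like the methyl or like the hydrogen.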